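This account rests on a few compounds, and the source may have more. Where it says the series, first, only, none or still open, it means among the compounds named here.

Compound 1 `COc1cc(/C=C/C(=O)c2sc(Nc3cccc(Cl)c3)nc2C)cc(OC)c1OC` and compound 2 `COc1cc(/C=C/C(=O)c2sc(Nc3ccc(C)cc3)nc2C)cc(OC)c1OC` share one core. In a functional assay on PC-3 cells (Homo sapiens) for cytotoxicity, read by MTT assay (on this read-out lower numbers stand for stronger inhibition and higher numbers for weaker inhibition), compound 1 reaches only the limit of the assay, > 25000 nM. Compound 2 likewise reaches only a limit in this assay, > 25000 nM. The change between them, (4-methylphenyl in place of 3-chlorophenyl on a nitrogen on an aromatic ring), therefore made a step that the two limits leave unreadable from compound 1 to compound 2. Compound 3 `COc1cccc(/C=C/C(=O)c2sc(Nc3cccc(Cl)c3)nc2C)c1` carries a different core, and the difference between the two cores is not broken down here. In this assay compound 3 also gives only a limit, > 25000 nM. Compound 4 `COc1cccc(/C=C/C(=O)c2sc(Nc3ccc(C)cc3)nc2C)c1` differs from compound 3 by 4-methylphenyl in place of 3-chlorophenyl on a nitrogen on an aromatic ring, the same change as from compound 1 to compound 2. The step from compound 3 to compound 4 is expected to be about a step that the limit leaves unreadable from compound 3 to compound 4, resting on (the limit of > 25000 nM in this assay, at which 3 of the 3 values shown sit). Compound 4 is thus expected to show roughly 50000 nM in this assay, most likely again as a limit.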

Compound 4, half-maximal inhibitory concentration: > 25000 nM
Compound 4: no number, only a limit (the forecaster's own chance of this, stated with the estimate: 85%); the middle value lies beyond the limit too.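

In this assay, going by these compounds alone, compound 3 and compound 4 both give only a limit, and no step between them can be read. The compounds shown leave open how strongly any of them acts on these cells, and whether 4-methylphenyl in place of 3-chlorophenyl changes that.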